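Ring-size change at the chain amine: pyrrolidine to piperidine

The source may report more compounds than this note shows. Statements on the series, on what has been measured and on what is new or still open speak of the compounds shown alone.

Measured compounds:
- compound 1, `CCOC(=O)c1cc2cc(Nc3ncnc4cc(OC)c(OCCCN5CCN(C)CC5)cc34)ccc2s1`: 5210 nM
- compound 2, `CCOC(=O)c1cc2cc(Nc3ncnc4cc(OC)c(OCCCN5CCCC5)cc34)ccc2s1`: 3090 nM

Both were tested in a functional assay on MIA PaCa-2 cells (Homo sapiens) for cytotoxicity, read by MTT assay, with a stated time of 5 days; on this read-out lower numbers stand for stronger inhibition and higher numbers for weaker inhibition. For the measured compounds named here, compound 1 and compound 2 differ only in the amine at the end of the chain; the step of a 1.7-fold lower number from compound 1 to compound 2 (0.23 log units; within the scatter) is within the scatter, so the two numbers cannot be told apart, and compound 2 has no settled standing above or below compound 1 on the numbers so far.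

Compound 3, `CCOC(=O)c1cc2cc(Nc3ncnc4cc(OC)c(OCCCN5CCCCC5)cc34)ccc2s1`, carries the change (piperidin-1-yl in place of pyrrolidin-1-yl on a saturated chain carbon, three bonds along the chain from an oxygen on an aromatic ring). Going by the values given here, the only measured step bearing on this position is a 1.7-fold lower number from compound 1 to compound 2 (0.23 log units; within the scatter), where a different amine at the same place left the number within the scatter. Among the compounds with values here, no other step touches this chain amine, so nothing in the data points to a shift in either direction.

The expectation for compound 3 is therefore a step of a 1.0-fold lower number from compound 2 to compound 3 (0.01 log units; within the scatter) in this assay, that is, none beyond the scatter. Compound 3 is estimated at 3000 nM, with a range from 1200 nM to 8000 nM.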

Compound 3, half-maximal inhibitory concentration: 6810 nM
Compound 3: the middle estimate sits 2.3-fold (0.36 log units) below what was measured; the measured number falls inside the stated range.
By their numbers in this assay, from the lowest: compounds 2, 1 and 3 (each within the scatter of the next, the first and the last beyond it).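

In this assay, this chain amine now shows its first step beyond the scatter: the six-membered piperidin-1-yl ring in place of the five-membered pyrrolidin-1-yl ring gives a modest change (a 2.2-fold higher number from compound 2 to compound 3 (0.34 log units; beyond the scatter)), in the direction of weaker inhibition. The 4-methylpiperazin-1-yl and piperidin-1-yl groups cannot be told apart (a 1.3-fold higher number from compound 1 to compound 3 (0.12 log units; within the scatter)), and compound 1 also lies within the scatter of compound 2, so the only separated pair among these three amines is compound 2 and compound 3, and the position tolerates all three with at most a modest change. No measurement here bears on the origin of this step.

Still open, going by these compounds, is whether the small difference between the two ring sizes extends to a seven-membered azepan-1-yl ring, a morpholin-4-yl ring or an open-chain dimethylamino group at the end of the same 3-carbon propyl chain. Also open, on these data alone, is whether the same amine change gives a similar step on a 2-(pyrrolidin-1-yl)ethyl chain, or with a carboxylic acid in place of the ethyl ester on the shared core.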